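Swapping the Methylphenyl Arm for a Methylindazole

This account rests on a few compounds, and the source may have more. Where it says the series, first, only, none or still open, it means among the compounds named here.

Compound 1, `COc1cc(-c2ccnc3cc(-c4ccc(C)cc4)nn23)cc(OC)c1OC`, is the reference point here. Among the measured compounds shown here, in a functional assay on MCF7 cells (Homo sapiens) for inhibition, read by CCK-8 assay, with a stated time of 48 h (on this read-out higher numbers stand for weaker inhibition and lower numbers for stronger inhibition), compound 1 gives 47 nM, the only finite number so far among the two compounds tested. Compound 2, `Cc1ccc(-c2cc3nccc(-c4ccc(F)cc4)n3n2)cc1`, carries a different arrangement of its aryl groups. For compound 2 this assay reports only a limit, > 10000 nM, as noted in the limit of > 10000 nM in this assay, at which 1 of the 2 values shown sits, so no numerical comparison with compound 1 is possible.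

Compound 3, `COc1cc(-c2ccnc3cc(-c4ccc5cnn(C)c5c4)nn23)cc(OC)c1OC`, has not yet been measured. It differs from compound 1 in one place: 1-methyl-1H-indazol-6-yl in place of 4-methylphenyl on an aromatic carbon. For the measured compounds named here, no measured pair shows what a change at this position does, so the expectation rests on compound 1 alone. Given the value of compound 1, 47 nM, compound 3 is expected to stay close, with any step from compound 1 to compound 3, a 1.2-fold lower number from compound 1 to compound 3 (0.07 log units; within the scatter), lying within the usual scatter. The estimated value for compound 3 is 40 nM, ranging from 10 nM to 200 nM.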

Compound 3, half-maximal inhibitory concentration: 279 nM
Estimate against measurement, compound 3: 7.0-fold (0.84 log units) below; measured number outside the range, above it.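

The aryl group on an aromatic carbon of the five-membered aromatic ring does not accept every change equally: with 1-methyl-1H-indazol-6-yl in place of 4-methylphenyl, the result is a 5.9-fold higher number from compound 1 to compound 3 (0.77 log units; beyond the scatter). Among the compounds shown here, this is the first measured step at this position, so it gives the first direct sign that the number responds to the group placed there. Compound 3 still gives a finite value, so the larger fused group does not abolish inhibition in this cell test, although 4-methylphenyl remains the better of the two groups.

As far as these compounds go, it remains open whether the ring nitrogens, the added ring or the methyl on it accounts for the step, and how a group such as 4-aminophenyl or an unmethylated indazole would compare at this place. Nothing in the data shown explains the step.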